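The source may report more compounds than this note shows. Statements on the series, on what has been measured and on what is new or still open speak of the compounds shown alone.

Values in a functional assay on Gurav cells (Homo sapiens) for inhibition, read by sulforhodamine B assay; a lower number here means a stronger inhibitor of growth, a higher number a weaker inhibitor of growth:
compound 1 `COc1ccc(-c2ccc(-c3ccc(-c4nc5ccccc5[nH]4)cc3)cc2)cc1` gives 38100 nM
compound 2 `CN(C)c1ccc(-c2ccc(-c3ccc(-c4nc5ccccc5[nH]4)cc3)cc2)cc1` gives 100000 nM
compound 3 `COc1ccc(-c2ccc(-c3ccc(-c4nc5c(O)cccc5[nH]4)cc3)cc2)cc1` gives 6630 nM

Compound 4 `CN(C)c1ccc(-c2ccc(-c3ccc(-c4nc5c(O)cccc5[nH]4)cc3)cc2)cc1` is not yet measured. Within the data shown here, the core of compound 3 differs from that of compound 1 by hydroxy in place of hydrogen on an aromatic carbon, and this gave a 5.7-fold lower number from compound 1 to compound 3 (0.76 log units; beyond the scatter), the lowest number so far. The change dimethylamino in place of methoxy on an aromatic carbon gave a 2.6-fold higher number from compound 1 to compound 2 (0.42 log units; beyond the scatter). Compound 4 carries dimethylamino in place of methoxy on an aromatic carbon, the same change at the same place, made on the core of compound 3. Among the measured compounds shown here, it has been seen only once, so the expected step from compound 3 to compound 4 in this assay is a 2.6-fold higher number from compound 3 to compound 4 (0.41 log units; beyond the scatter), resting on the single earlier step of a 2.6-fold higher number from compound 1 to compound 2 (0.42 log units; beyond the scatter). Compound 4 is therefore expected to give about 17000 nM, most likely between 7000 nM and 50000 nM.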

Compound 4, concentration for 50% growth inhibition: 8210 nM
Estimate against measurement, compound 4: 2.1-fold (0.32 log units) above, within the range that was stated.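

In this assay, dimethylamino in place of methoxy on the core of compound 3 gives a 1.2-fold higher number from compound 3 to compound 4 (0.09 log units; within the scatter), and this step does not differ from the earlier one on the core of compound 1: the same change on two cores in this assay, a 2.6-fold higher number (0.42 log units; beyond the scatter) from compound 1 to compound 2 and a 1.2-fold higher number (0.09 log units; within the scatter) from compound 3 to compound 4, 2.1-fold (0.33 log units) apart, within the scatter of two such steps

Hydroxy in place of hydrogen gives a 12-fold lower number from compound 2 to compound 4 (1.09 log units; beyond the scatter), and this step also agrees with its earlier counterpart: the same change on two cores in this assay, a 5.7-fold lower number (0.76 log units; beyond the scatter) from compound 1 to compound 3 and a 12-fold lower number (1.09 log units; beyond the scatter) from compound 2 to compound 4, 2.1-fold (0.33 log units) apart, within the scatter of two such steps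

Both changes therefore carried from one core to the other within the scatter, but this rests on a single pair of steps for each change and does not show that they would carry to any other core.

Open, going by these compounds, is whether an amine or a methoxy group in place of the hydroxy would give a similar step. On these data alone, a longer alkoxy chain or a carboxylic acid in place of the methoxy is also open.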